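Allyl to Methyl on a Triazene Amide Core

The source may hold more compounds than are shown below. What is called first, only, known or untested is meant among the compounds shown, and "the series" means these compounds.

Measured so far:
Compound 1, `CN(C)/N=N/c1ccc(C#N)cc1C(N)=O`: in a functional assay on L1210 cells (Mus musculus) for antiproliferative activity (a higher number here means a more potent compound, by a factor of ten per unit of this negative logarithm, a lower number a less potent compound), compound 1 gives 3.46.
Compound 2, `C=CCN(C)/N=N/c1ccccc1C(N)=O`: in this assay compound 2 gives 3.43.

Compound 2 holds the lower of the two numbers, yet its nearest neighbour, compound 1, stands only within the scatter of it, so the two are not told apart. The next compound, compound 3, `CN(C)/N=N/c1ccccc1C(N)=O`, follows from compound 2 by one change: hydrogen in place of vinyl on a saturated chain carbon bound to an amine nitrogen, that is, allyl(methyl)amino becomes dimethylamino. With compound 1 carrying the same dimethylamino group at a similar level, no step beyond the scatter is expected in this assay. Compound 3 is therefore estimated at 3.5, within 3 to 4, a step of a number 0.07 log units higher from compound 2 to compound 3 (within the scatter).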

Compound 3, logarithm of the reciprocal of the active concentration, log(1/C): 3.31
Estimate against measurement, compound 3: 0.19 log units above, and the stated range covers the measured number.
By their numbers in this assay, from the lowest: compounds 3, 2 and 1 (each within the scatter of the next).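

In this assay, allyl to methyl on the amine nitrogen gives a number 0.12 log units lower from compound 2 to compound 3 (within the scatter), so this change on a saturated chain carbon bound to an amine nitrogen does not separate the two compounds. Hydrogen in place of cyano on an aromatic carbon gives a number 0.15 log units lower from compound 1 to compound 3 (within the scatter), so that change does not separate its pair either. Nothing measured here offers a cause for either step. The compounds shown leave open whether a longer chain, such as butyl, in place of allyl would give a step beyond the scatter. They also leave open whether a carboxylic acid in place of the nitrile would do so.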